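Cyclopropyl for Phenyl on the Amide of Compound 2

The source may report more compounds than this note shows. Statements on the series, on what has been measured and on what is new or still open speak of the compounds shown alone.

Compound 1 `[O-][S+](CCNC1CCN(Cc2ccc(F)cc2)CC1)C(c1ccc(F)cc1)c1ccc(F)cc1`: 26.5 nM
Compound 2 `O=C(c1ccccc1)N1CCC(NCCSC(c2ccc(F)cc2)c2ccc(F)cc2)CC1`: 2.03 nM
Compound 3 `O=C(c1ccccc1)N1CCC(NCC[S+]([O-])C(c2ccc(F)cc2)c2ccc(F)cc2)CC1`: 585 nM

In an assay on membranes from Cortex for displacement of a labelled ligand from Sigma non-opioid intracellular receptor 1 (Cavia porcellus), read by scintillation counting, with a stated time of 120 min (on this read-out lower numbers stand for stronger inhibition and higher numbers for weaker inhibition), compound 2 gives the lowest number of the three, and the gap to compound 3 with 585 nM is far wider than the gap to compound 1 with 26.5 nM. Compound 4 `O=C(C1CC1)N1CCC(NCCSC(c2ccc(F)cc2)c2ccc(F)cc2)CC1` differs from compound 2 by cyclopropyl in place of phenyl on a carbonyl carbon. For the measured compounds named here, the only measured step, a 22-fold higher number from compound 1 to compound 3 (1.34 log units; beyond the scatter), concerns the group on the amine nitrogen in the ring rather than the group on the carbonyl carbon, so no measured pair bears directly on this exchange. Without a guiding precedent, only a modest rise in this assay is expected, a 2.5-fold higher number from compound 2 to compound 4 (0.39 log units; beyond the scatter). Compound 4 is therefore estimated at 5 nM, with a range from 1.5 nM to 20 nM.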

Compound 4, inhibition constant: 46.4 nM
The estimate for compound 4 lay 9.3-fold (0.97 log units) below the measured number; the whole stated range lies below it.
By their numbers in this assay, from the lowest: compound 2; then compounds 1 and 4 (each within the scatter of the next); then compound 3.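

In this assay, the group on the carbonyl carbon has a large bearing on the number: cyclopropyl in place of phenyl gives a 23-fold higher number from compound 2 to compound 4 (1.36 log units; beyond the scatter) and so gives up most of the advantage of compound 2. For the compounds shown here, the earlier step concerned only the group on the amine nitrogen in the ring, so this is the only reading at this place. No evidence is available to account for the size of this step. Going by these compounds, it remains open whether a cyclohexyl, pyridyl or 4-fluorophenyl group on the carbonyl carbon would keep the number of compound 2 or lose as much as cyclopropyl.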